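Shortening the alkyl chain on a thymidine-like core

A few compounds are considered here, and "the series" means these few. Any claim that something is new, unique, unknown or untested is made for them only; others in the source may bear on it.

Compound 1: `CCCCCCCCc1cn([C@H]2C[C@H](O)[C@@H](CO)O2)c(=O)[nH]c1=O` — 140 ug/mL
Compound 2: `CCc1cn([C@H]2C[C@@H]3OP(=O)(O)OC[C@H]3O2)c(=O)[nH]c1=O` — > 500 ug/mL
Compound 3: `CCCCCCc1cn([C@H]2C[C@H](O)[C@@H](CO)O2)c(=O)[nH]c1=O` — 173 ug/mL
Compound 4: `CCCCc1cn([C@H]2C[C@H](O)[C@@H](CO)O2)c(=O)[nH]c1=O` — not yet measured

Of the compounds shown here, three have been tested in a functional assay on Raji cells (Homo sapiens); a higher number here means a weaker inhibitor, a lower number a stronger inhibitor. Compound 1 gives 140 ug/mL and compound 3 gives 173 ug/mL; the step of a 1.2-fold higher number from compound 1 to compound 3 (0.09 log units; within the scatter) lies within the scatter. Compound 2 carries a different sugar part, and its result in this assay is a limit, > 500 ug/mL, not a number; it is the only limit among the three values (the limit of > 500 ug/mL in this assay, at which 1 of the 3 values shown sits). Compound 3 therefore has the highest of the two numbers, with compound 1 its nearest neighbour within the scatter.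

The new compound 4 differs from compound 3 as follows: hydrogen in place of ethyl on a saturated chain carbon, four bonds along the chain from an aromatic carbon. Within the data shown here, the one measured step that bears on this change is the one from compound 1 to compound 3, which was the same kind of shortening and stayed within the scatter. The account therefore expects no step beyond the scatter in this assay, with a slight lean toward a higher number, so that compound 4 is expected to show a 1.4-fold higher number from compound 3 to compound 4 (0.14 log units; within the scatter). Compound 4 is estimated at 240 ug/mL, with a range from 110 ug/mL to 500 ug/mL.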

Compound 4, concentration for 50% inhibition: > 500 ug/mL
Compound 4: only a limit was reported; the forecaster's own chance of this, stated with the estimate: 30%; at least 2.0-fold (0.31 log units) between middle value and limit.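

In this assay compound 4 gives > 500 ug/mL, which is a limit of the assay and not a number: the limit of > 500 ug/mL in this assay, at which 2 of the 4 values shown sit.

Replacing ethyl with hydrogen at this place in the chain therefore gives an at least 2.8-fold higher number from compound 3 to compound 4 (0.46 log units; beyond the scatter), whereas the earlier shortening, a 1.2-fold higher number from compound 1 to compound 3 (0.09 log units; within the scatter), showed no change that could be told from the scatter. The full shortening gives an at least 3.5-fold higher number from compound 1 to compound 4 (0.55 log units; beyond the scatter), so among these three compounds, which share the same core, the chain can lose length without a readable effect only down to compound 3, and the further loss is the first change at this position to take the reading beyond the scatter.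

From the compounds shown here alone, the true size of both new steps stays open, since they rest on a limit, and compound 2 differs from compound 4 in more than one place, so it adds nothing to this comparison. The compounds shown also leave open whether a chain longer than that of compound 1, or a hydroxyl or an amine at the end of the chain, would give a lower number in this assay.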